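Chloro removal in a quinone series: cytotoxicity notes

The compounds below may be only part of what the source reports. "The series", "measured", "known", "first", "only" and "open" are said of these compounds alone.

Compound 1 `Cc1cc(Cl)c2c(c1O)C(=O)C=CC2=O`, compound 2 `COc1cc(C)cc2c1C(=O)C=CC2=O` and compound 3 `COc1cc(C)c(Cl)c2c1C(=O)C=CC2=O` are measured; compound 4 `Cc1ccc2c(c1O)C(=O)C=CC2=O` is not. In a functional assay on SNO cells (Homo sapiens) for cytotoxicity, read by XTT assay, with a stated time of 24 h (on this read-out lower numbers stand for stronger inhibition and higher numbers for weaker inhibition), compound 1 gives 9400 nM, compound 2 gives 22500 nM and compound 3 gives 24600 nM. Compound 1 holds the lowest number, with compound 2 and compound 3 both beyond the scatter from it. The step of a 1.1-fold lower number from compound 3 to compound 2 (0.04 log units; within the scatter) follows the change (hydrogen in place of chloro on an aromatic carbon). The change hydrogen in place of chloro on an aromatic carbon is the same kind of change, but around its place the carbon is meta to a methyl group and para to a hydroxy group, whereas in the earlier change it is ortho to a methyl group and para to a methoxy group. The difference between the cores of compound 1 and compound 3 is not broken down here. Because a 1.1-fold lower number from compound 3 to compound 2 (0.04 log units; within the scatter) lies within the scatter, a similarly small step is expected, a 1.0-fold higher number from compound 1 to compound 4 (0.00 log units; within the scatter). Compound 4 is thus expected to give 9500 nM in this assay, estimated between 4000 nM and 22000 nM.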

Compound 4, half-maximal inhibitory concentration: 19000 nM
Estimate against measurement, compound 4: 2.0-fold (0.30 log units) below; the range from low to high includes it.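

In this assay, hydrogen in place of chloro on an aromatic carbon gives a 2.0-fold higher number from compound 1 to compound 4 (0.31 log units; beyond the scatter), a modest step. Set beside the earlier step on the other core, the gap stays within the scatter, so nothing here separates the behaviour of this change on the two cores: the same change on two cores in this assay, a 1.1-fold lower number (0.04 log units; within the scatter) from compound 3 to compound 2 and a 2.0-fold higher number (0.31 log units; beyond the scatter) from compound 1 to compound 4, 2.2-fold (0.34 log units) apart, within the scatter of two such steps. Two pairs do not show that the change carries over unaltered to other cores in the series, and they do not say what sets the size of either step.

As far as these compounds go, only chloro and hydrogen appear at this place, so the outcome with fluoro, bromo or an amine there remains open. Also open, from the compounds shown here alone, is how the change behaves on a core bearing a longer chain instead of the methyl group.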